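Compound 3 to compound 4: hydrogen in place of chloro

This account rests on a few compounds, and the source may have more. Where it says the series, first, only, none or still open, it means among the compounds named here.

In an ADME assay on microsomes from liver (Mus musculus) for metabolic stability, read by LC-MS, with NADPH named in the record, with a stated time of 60 min, tested at 1 uM, in the absence of a further agent (on this read-out lower numbers stand for a less stable compound and higher numbers for a more stable compound), compound 3 (`COc1ccc(-c2c(C)nc3c(N4CC[C@@H](NC(C)=O)C4)cc(Cl)nn23)cc1OC`) gives > 95%, which is a limit and not a number. Compound 1 (`COc1ccc(-c2c(C)nc3c(N4CC[C@@H](NC(C)=O)C4)cc(C)nn23)cc1OC`) gives > 95%, also a limit. Compound 2 (`CC(=O)N[C@@H]1CCN(c2cc(C)nn3c(-c4cccs4)c(C)nc23)C1`) gives > 95%, again a limit. Among the measured compounds shown here, the series so far therefore comes down to the limit of > 95% in this assay, at which 3 of the 3 values shown sit.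

Compound 4 (`COc1ccc(-c2c(C)nc3c(N4CC[C@@H](NC(C)=O)C4)ccnn23)cc1OC`) has hydrogen in place of chloro on an aromatic carbon.

For the measured compounds named here, two measured steps bear on this change. The closer one is a step that the two limits leave unreadable from compound 1 to compound 3, with chloro in place of methyl on the same aromatic carbon. The other is a step that the two limits leave unreadable from compound 1 to compound 2, with thiophen-2-yl in place of 3,4-dimethoxyphenyl. Neither has a readable size, and neither gives any sign of movement in this assay, so no step beyond the scatter is expected. The estimated change is a step that the limit leaves unreadable from compound 3 to compound 4. For compound 4 the estimated value is 96%, with an expected range from 85% to 100%.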

Compound 4, percent of the compound remaining: > 95%
Compound 4 ended at the assay's limit; the forecaster's own chance of this, stated with the estimate: 70%; the middle value lies beyond the limit too.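

Among the compounds shown here, compound 4 sits at the same limit as compound 1 and compound 3 in this assay and is not a number there, so no step from compound 1 or compound 3 to compound 4 can be read. On these data alone, how far these compounds truly differ in stability, and which change to the shared core would bring a value under the limit, stays open.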